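Diol in place of sulfonamide on the piperidine side chain

The source may hold more compounds than are shown below. What is called first, only, known or untested is meant among the compounds shown, and "the series" means these compounds.

Measured compounds:
compound 1, `CNC(=O)C[C@@H]1C[C@@H](c2ccc(Cl)c(Cl)c2)[C@H](NC(=O)c2cc(-c3c(Cl)cnn3C)c(Cl)o2)CN1`, 450 nM
compound 2, `Cn1ncc(Cl)c1-c1cc(C(=O)N[C@@H]2CN[C@H](CCNS(C)(=O)=O)C[C@H]2c2ccc(F)c(F)c2)oc1Cl`, 920 nM

The two compounds share a core and differ in the substituent on the saturated chain carbon bound to the ring and in the halogen pattern of the aryl ring. In a functional assay on HCT-116 cells (Homo sapiens) for antiproliferative activity, read by sulforhodamine B assay, with a stated time of 72 h (a higher number here means a weaker inhibitor, a lower number a stronger inhibitor), compound 2 gives 920 nM, the higher of the two numbers recorded; compound 1 gives 450 nM, a gap that lies beyond the usual scatter of the measurement.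

Compound 3, `Cn1ncc(Cl)c1-c1cc(C(=O)N[C@@H]2CN[C@H](CC(O)CO)C[C@H]2c2ccc(F)c(F)c2)oc1Cl`, has not yet been measured. It keeps the aryl ring and core of compound 2 and changes only the side chain: 1,2-dihydroxyethyl in place of (methanesulfonamido)methyl on a saturated chain carbon bound to a saturated ring carbon. Within the data shown here, no measured pair shows this exact exchange, so the size of the step cannot be read from the data. The swap replaces one hydrogen-bond donor group with another of similar reach, and a step in this assay no larger than the scatter, in either direction, is expected a 1.2-fold higher number from compound 2 to compound 3 (0.08 log units; within the scatter). Compound 3 is therefore estimated at 1100 nM, with a range from 450 nM to 2800 nM.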

Compound 3, half-maximal inhibitory concentration: 800 nM
Estimate against measurement, compound 3: 1.4-fold (0.14 log units) above; low and high end bracket the measured number.
By their numbers in this assay, from the lowest: compounds 1, 3 and 2 (each within the scatter of the next, the first and the last beyond it).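

In this assay, among these compounds, placing 1,2-dihydroxyethyl in place of (methanesulfonamido)methyl on a saturated chain carbon bound to a saturated ring carbon gives a 1.2-fold lower number from compound 2 to compound 3 (0.06 log units; within the scatter), the first step that can be read at a single place. The step lies within the scatter, so this assay does not tell these two side chains apart, even though the sulfur and nitrogen of the leaving group are gone and the entering group carries its hydrogen-bond donors on two hydroxyl groups. Nothing measured here explains why the two side chains read alike.

On these data alone, whether this position would respond to a side chain ending in a primary amine or a carboxylic acid, or to a longer chain such as 3,4-dihydroxybutyl, remains open, since the two groups compared here do not show how far the position tolerates change. Compound 1 differs from compound 2 and from compound 3 in both the side chain and the halogen pattern of the aryl ring, so the share of each change in its number cannot be read from these compounds.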